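Selenium-Bearing Replacement Carried Over to a Second Core

The compounds below may be only part of what the source reports. "The series", "measured", "known", "first", "only" and "open" are said of these compounds alone.

Four compounds are compared here, built on two different cores. Compound 1 `CS/C(=N\C(=O)c1csc([N+](=O)[O-])c1)NC(=O)c1csc([N+](=O)[O-])c1` and compound 3 `O=C(/N=C(/NC(=O)c1csc([N+](=O)[O-])c1)[Se]Cc1ccccc1)c1csc([N+](=O)[O-])c1` share one core; compound 2 `CS/C(=N\C(=O)c1cc2ccccc2s1)NC(=O)c1cc2ccccc2s1` and compound 4 `O=C(/N=C(/NC(=O)c1cc2ccccc2s1)[Se]Cc1ccccc1)c1cc2ccccc2s1` share another. The difference between the two cores is not broken down here.

Growth inhibition was measured in a functional assay on HepG2 cells (Homo sapiens) for cytotoxicity, read by MTT assay, with a stated time of 72 h; on this read-out lower numbers stand for stronger inhibition of growth and higher numbers for weaker inhibition of growth. In this assay compound 1 gives 63400 nM, compound 3 gives 34100 nM, and compound 2 gives 15800 nM, the lowest of the three numbers.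

Within the first core one structural change has already been measured: a group of 8 heavy atoms (7 carbon, 1 selenium; one six-membered aromatic ring of carbon only) in place of a group of 2 heavy atoms (1 carbon, 1 sulfur; no ring), on a carbon with a double bond to nitrogen. This change gave a 1.9-fold lower number from compound 1 to compound 3 (0.27 log units; within the scatter), so on that core it made no difference that can be separated from measurement noise.

The same change is now applied to the second core: a group of 8 heavy atoms (7 carbon, 1 selenium; one six-membered aromatic ring of carbon only) in place of a group of 2 heavy atoms (1 carbon, 1 sulfur; no ring), on a carbon with a double bond to nitrogen. The place is the same as before, a carbon with a double bond to nitrogen whose other neighbours are two amide-type nitrogens, so this is the same change, seen a second time among these compounds.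

Going by the values given here, with only one earlier instance to go on, the step from compound 2 to compound 4 is expected to be about as small as the earlier one, because compound 1 to compound 3 showed a 1.9-fold lower number from compound 1 to compound 3 (0.27 log units; within the scatter); the expected step is a 1.6-fold lower number from compound 2 to compound 4 (0.20 log units; within the scatter). Compound 4 is therefore estimated at 10000 nM, with a likely range from 4000 nM to 25000 nM.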

Compound 4, concentration for 50% growth inhibition: 21000 nM
Compound 4: the middle estimate sits 2.1-fold (0.32 log units) below what was measured; measured number inside the range.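

On the second core, putting the selenium-bearing group with its six-membered aromatic ring in place of methylsulfanyl gives a 1.3-fold higher number from compound 2 to compound 4 (0.12 log units; within the scatter) in this assay, so once again the change cannot be told apart from measurement noise. The result on the first core therefore carried over to the second in the sense that mattered: neither core shows a measurable effect of the change, and the two steps agree with each other: the same change on two cores in this assay, a 1.9-fold lower number (0.27 log units; within the scatter) from compound 1 to compound 3 and a 1.3-fold higher number (0.12 log units; within the scatter) from compound 2 to compound 4, 2.5-fold (0.39 log units) apart, within the scatter of two such steps This does not prove that the change has no effect at all, only that any effect is too small to see in this read-out, and two cores cannot show that the same would hold on a third.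

The entering group differs from methylsulfanyl both in having selenium in place of sulfur and in carrying the aromatic ring, so the compounds shown leave open what each of these alone would do, for example with a methyl group on selenium. They also leave open whether a quite different group on the same carbon, such as an amine or a longer chain, would shift the number beyond the scatter.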